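From 2-Hydroxyethyl to Carboxy on a Shared Core

The source may hold more compounds than are shown below. What is called first, only, known or untested is meant among the compounds shown, and "the series" means these compounds.

Of the compounds shown here, three built on a shared core have numbers so far in a functional assay on LNCaP cells (Homo sapiens) for antiproliferative activity (on this read-out higher numbers stand for weaker inhibition and lower numbers for stronger inhibition), as the read-out. Here compound 1 `Cn1ncc(Cl)c1-c1cc(C(=O)N[C@@H]2CN[C@H](CCNS(C)(=O)=O)C[C@H]2c2ccc(F)c(F)c2)oc1Cl` gives 50 nM and compound 2 `Cn1ncc(Cl)c1-c1cc(C(=O)N[C@@H]2CN[C@H](CC(O)CO)C[C@H]2c2ccc(F)c(F)c2)oc1Cl` gives 100 nM as its result. Compound 3 `Cn1ncc(Cl)c1-c1cc(C(=O)N[C@@H]2CN[C@H](CCCO)C[C@H]2c2ccc(Cl)c(Cl)c2)oc1Cl` stands at 210 nM as the highest number of the three, beyond the scatter from both of the others.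

Compound 4 `Cn1ncc(Cl)c1-c1cc(C(=O)N[C@@H]2CN[C@H](CC(=O)O)C[C@H]2c2ccc(Cl)c(Cl)c2)oc1Cl` has not been measured yet. It differs from compound 3 in one place, with carboxy in place of 2-hydroxyethyl on a saturated chain carbon bound to a saturated ring carbon.

Among the measured compounds shown here, only one measured step offers a guide, a swap on the same kind of side chain, where a 2.0-fold higher number from compound 1 to compound 2 (0.30 log units; within the scatter) keeps the pair within the scatter of each other. That small step argues against expecting a dramatic shift. It is an imperfect guide, though, since none of the three measured compounds carries a carboxy group. A cautious lean toward weaker inhibition is therefore all that can be offered, and the range stays wide. The estimate is a 2.4-fold higher number from compound 3 to compound 4 (0.38 log units; beyond the scatter) in this assay as a modest move. For compound 4 the expected value is 500 nM with an estimated range from 150 nM to 2000 nM in this expectation.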

Compound 4, half-maximal inhibitory concentration: 640 nM
Estimate against measurement, compound 4: 1.3-fold (0.11 log units) below; low and high end bracket the measured number.
By their numbers in this assay, from the lowest: compounds 1 and 2 (each within the scatter of the next); then compound 3; then compound 4.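

On this side chain, this assay now shows a step that lies beyond the scatter: a 3.0-fold higher number from compound 3 to compound 4 (0.48 log units; beyond the scatter), with the higher number meaning weaker inhibition. Among the compounds shown here, the only earlier step at this place, a 2.0-fold higher number from compound 1 to compound 2 (0.30 log units; within the scatter), stayed within the scatter and involved neither of these groups, so this is the first sign that a change on a saturated chain carbon bound to a saturated ring carbon can shift the result measurably. The effect comes from a swap that leaves the counts of heavy atoms, hydrogen-bond donors and hydrogen-bond acceptors unchanged, with one carbon traded for an oxygen and a double bond added outside aromatic rings, but no evidence here explains why this swap gives weaker inhibition.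

The compounds shown leave open whether a primary amide or a methyl ester in place of the carboxy would give a similar number, and whether a longer chain ending in the carboxylic acid would do the same. They also leave open whether the same swap would produce a step of similar size on the core of compound 1.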